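A few compounds are considered here, and "the series" means these few. Any claim that something is new, unique, unknown or untested is made for them only; others in the source may bear on it.

Compounds measured:
- compound 1, `Cc1cc(Nc2cc(-c3ccccc3)[nH]n2)n2nc(SCCc3ccccc3)nc2n1`: 2700 nM
- compound 2, `Cc1cc(Nc2cc(-c3ccccc3)[nH]n2)n2nc(SCc3ccc([N+](=O)[O-])cc3)nc2n1`: 5060 nM
- compound 3, `Cc1cc(Nc2cc(-c3ccccc3)[nH]n2)n2nc(SCc3ccccc3Br)nc2n1`: 3020 nM

In a functional assay on MCF7 cells (Homo sapiens) for inhibition, read by MTT assay, with a stated time of 72 h (on this read-out higher numbers stand for weaker inhibition and lower numbers for stronger inhibition), compound 1 gives 2700 nM, the smallest of the three numbers shown, yet its separation from the others is slight: compound 3 is nearest, with a 1.1-fold higher number from compound 1 to compound 3 (0.05 log units; within the scatter), and compound 2 is furthest, with a 1.9-fold higher number from compound 1 to compound 2 (0.27 log units; within the scatter). Between those two, a 1.7-fold lower number from compound 2 to compound 3 (0.22 log units; within the scatter) also stays within the scatter.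

Compound 4 is `Cc1cc(Nc2cc(-c3ccccc3)[nH]n2)n2nc(SCc3ccc(Cl)cc3)nc2n1`. It differs from compound 1 by 4-chlorophenyl in place of benzyl on a saturated chain carbon bound to a sulfur. The two steps already measured at this same place, the change to 4-nitrophenyl and the change to 2-bromophenyl, are the ones that bear on this, and neither moved the number beyond the scatter. On that basis a step of similar size is expected in this assay, without a clear direction. Compound 4 is therefore expected to give 3200 nM, with a range from 1600 nM to 6500 nM. This estimate means a step of a 1.2-fold higher number from compound 1 to compound 4 (0.07 log units; within the scatter), which is expected to stay within the scatter.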

Compound 4, half-maximal inhibitory concentration: 8260 nM
For compound 4 the middle estimate is 2.6-fold (0.41 log units) below the measured one, outside the stated range (above it).
By their numbers in this assay, from the lowest: compounds 1, 3, 2 and 4 (each within the scatter of the next, the first and the last beyond it).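

In this assay, for the compounds shown here, this position no longer looks indifferent: 4-chlorophenyl in place of benzyl on a saturated chain carbon bound to a sulfur gives the first step here beyond the scatter (a 3.1-fold higher number from compound 1 to compound 4 (0.49 log units; beyond the scatter)), and the change from 2-bromophenyl also passes it (a 2.7-fold higher number from compound 3 to compound 4 (0.44 log units; beyond the scatter)). Chloro in place of nitro on an aromatic carbon stays within the scatter (a 1.6-fold higher number from compound 2 to compound 4 (0.21 log units; within the scatter)), so the ring substituent matters here for some changes but not for all, and compound 2 cannot be separated from compound 4. Nothing given here accounts for the larger step.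

Read one bond further out, the step from compound 1 is phenethyl to 4-chlorobenzyl, so the effects of chain and chlorine remain unseparated. From the compounds shown here alone, a 4-chlorophenethyl or unsubstituted benzyl group on the sulfur would separate them, and how an amine or a carboxylic acid on the ring would behave remains open.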